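Sulfonamide series: chloro moved onto the five-membered ring

The source may hold more compounds than are shown below. What is called first, only, known or untested is meant among the compounds shown, and "the series" means these compounds.

Compound 1 `COc1ccc(S(=O)(=O)Nc2cccc3cc[nH]c23)cc1` gives 1.5 ug/mL in a functional assay on MC-38 cells (Mus musculus) for antiproliferative activity, read by colorimetric assay and MTT assay; on this read-out lower numbers stand for stronger inhibition and higher numbers for weaker inhibition. Compound 2 `COc1ccc(S(=O)(=O)Nc2ccc(Cl)c3cc[nH]c23)cc1` carries chloro in place of hydrogen on an aromatic carbon and gives 0.65 ug/mL in this assay; the step is a 2.3-fold lower number from compound 1 to compound 2 (0.36 log units; beyond the scatter). Compound 3 `O=[N+]([O-])c1ccc(S(=O)(=O)Nc2cccc3cc[nH]c23)cc1` differs from compound 1 by nitro in place of methoxy on an aromatic carbon. In this assay compound 3 gives 7.2 ug/mL, the highest number of the three; the step is a 4.8-fold higher number from compound 1 to compound 3 (0.68 log units; beyond the scatter). Compound 4 `O=[N+]([O-])c1ccc(S(=O)(=O)Nc2cccc3c(Cl)c[nH]c23)cc1` is unmeasured and differs from compound 3 by chloro in place of hydrogen on an aromatic carbon. This is the same kind of change as from compound 1 to compound 2, not the same: there the chloro sits on a six-membered aromatic ring of carbon only, ortho to a fused ring, meta to a fused ring, para to a large group; here on a five-membered aromatic ring with 1 nitrogen, two ring bonds from the ring nitrogen. Beside a 2.3-fold lower number from compound 1 to compound 2 (0.36 log units; beyond the scatter), the expected step of a 1.4-fold lower number from compound 3 to compound 4 (0.16 log units; within the scatter) is set smaller, because the precedent a 2.3-fold lower number from compound 1 to compound 2 (0.36 log units; beyond the scatter) comes from a different ring. The estimate for compound 4 is 5 ug/mL, between 2.5 ug/mL and 10 ug/mL.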

Compound 4, half-maximal inhibitory concentration: 0.34 ug/mL
Compound 4: middle estimate off by 15-fold (1.17 log units), on the high side; the measured number lies below the stated range.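

In this assay, chloro in place of hydrogen lowers the number on both cores, and a 21-fold lower number from compound 3 to compound 4 (1.33 log units; beyond the scatter) is much the larger step: the same change on two cores in this assay, a 2.3-fold lower number (0.36 log units; beyond the scatter) from compound 1 to compound 2 and a 21-fold lower number (1.33 log units; beyond the scatter) from compound 3 to compound 4, 9.2-fold (0.96 log units) apart, beyond the scatter of two such steps
The direction of the change therefore holds across these two pairs, but the size of the step does not carry from one core to the other. The pairs differ both in the ring that bears the chloro and in methoxy against nitro, and these data do not show which of the two accounts for the gap.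

On these data alone, it remains open what chloro on the five-membered aromatic ring does when methoxy stands in place of nitro. Also open, as far as these compounds go, is whether bromo, methyl or nitrile at that same place would follow chloro.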